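A few compounds are considered here, and "the series" means these few. Any claim that something is new, unique, unknown or untested is made for them only; others in the source may bear on it.

Compound 3 `CS(=O)(=O)c1cnc(O[C@H]2CC[C@H](OC3CCN(C(=O)C4(C(F)(F)F)CC4)CC3)CC2)cn1` gives the highest number of the three measured compounds in a functional assay on isolated protein for agonist activity at Glucose-dependent insulinotropic receptor (Rattus norvegicus), read by HTRF and cAMP accumulation (a lower number here means that less compound is needed, a higher number that more compound is needed for the effect), with 1380 nM. Compound 1 `C[C@H](CF)OC(=O)N1CCC(O[C@H]2CC[C@H](Oc3cnc(S(C)(=O)=O)cn3)CC2)CC1` gives 317 nM in this assay, and compound 2 `C[C@@H](CF)OC(=O)N1CCC(O[C@H]2CC[C@H](Oc3cnc(S(C)(=O)=O)cn3)CC2)CC1` gives 356 nM; the step of a 1.1-fold higher number from compound 1 to compound 2 (0.05 log units; within the scatter) rests on (the fact that compounds 1 and 2 differ only in the configuration as drawn). The steps of a 4.4-fold higher number from compound 1 to compound 3 (0.64 log units; beyond the scatter) and a 3.9-fold higher number from compound 2 to compound 3 (0.59 log units; beyond the scatter) are modest. Compound 4 `CS(=O)(=O)c1cnc(O[C@H]2CC[C@H](OC3CCN(CC4(C(F)(F)F)CCC4)CC3)CC2)cn1` carries (1-(trifluoromethyl)cyclobutyl)methyl in place of (1-(trifluoromethyl)cyclopropyl)carbonyl on an amine nitrogen in a ring. Among the compounds with values here, no measured step exchanges a carbonyl-bearing group for one without a carbonyl, so the two steps leading into compound 3 bear on this change only loosely, showing that alterations at this nitrogen shift the number modestly. The expected step is a 1.8-fold higher number from compound 3 to compound 4 (0.26 log units; within the scatter), toward a higher number with wide uncertainty. Compound 4 is therefore estimated at 2500 nM, within a range from 500 nM to 12000 nM.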

Compound 4, half-maximal effective concentration: 80 nM
Compound 4: the middle estimate sits 31-fold (1.49 log units) above what was measured; measured number outside the range, below it.
By their numbers in this assay, from the lowest: compound 4; then compounds 1 and 2 (each within the scatter of the next); then compound 3.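

Within the data shown here, on the amine nitrogen in a ring, (1-(trifluoromethyl)cyclobutyl)methyl in place of (1-(trifluoromethyl)cyclopropyl)carbonyl gives a 17-fold lower number from compound 3 to compound 4 (1.24 log units; beyond the scatter) in this assay, so this position can move the number much further than the earlier steps showed. The new group also differs beyond the scatter from the two groups with a carbonyl and a fluorinated chain, with a 4.5-fold lower number from compound 2 to compound 4 (0.65 log units; beyond the scatter) and a 4.0-fold lower number from compound 1 to compound 4 (0.60 log units; beyond the scatter). Nothing given here explains the size of this shift.

The ring size and the carbonyl change together, so the compounds shown leave open which of the two accounts for the shift. From the compounds shown here alone, how a (1-(trifluoromethyl)cyclopropyl)methyl group or a cyclobutylmethyl group without the trifluoromethyl would compare also remains open.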